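The source may hold more compounds than are shown below. What is called first, only, known or untested is meant among the compounds shown, and "the series" means these compounds.

A small set of compounds sharing one core was examined in an ADME assay on microsomes from liver (Rattus norvegicus) for metabolic stability, read by LC-MS, with a stated time of 1 h, at 37 degrees C, tested at 4 uM (a lower number here means that less of the compound is left, a higher number that more of the compound is left), and the record so far is thin. Among the measured compounds shown here, compound 2 (`O=C1c2ccc(OCc3cccc(-c4ccccc4)c3)cc2CN1C1CCCC1`) gives 38% and is the only one with a number. Compound 1 (`O=C1c2ccc(OCc3cccc(-c4ccc(Cl)cc4F)c3)cc2CN1C1CCCC1`) has the entry "not determined" (no result reported) in this assay and so offers no value to compare. Compound 3 (`O=C1c2ccc(OCc3cccc(-c4ccc(C(F)(F)F)cc4F)c3)cc2CN1C1CCCC1`) also has the entry "not determined" (no result reported) in this assay and therefore has no place on the scale, which leaves it without a measured starting point.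

Compound 4 (`COc1ccc(-c2cccc(COc3ccc4c(c3)CN(C3CCCC3)C4=O)c2)cc1C(=O)O`) has not yet been measured. It differs from compound 3 in one group. The change is 3-carboxy-4-methoxyphenyl in place of 2-fluoro-4-(trifluoromethyl)phenyl on an aromatic carbon with 3-carboxy-4-methoxyphenyl in place of 2-fluoro-4-(trifluoromethyl)phenyl on an aromatic carbon. No measured step between any two of these compounds exists, so the size of this change cannot be read from the data. Taking compound 2 at 38% as the only anchor, a moderate rise beyond the usual scatter is expected for compound 4, although this direction is a judgement and the numbers do not show it. In this assay the estimated value for compound 4 is 68% with an expected range from 40% to 92% in a repeat measurement.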

Compound 4, percent of the compound remaining: 84%
Compound 4: the middle estimate sits 16 percentage points below what was measured; the measured number falls inside the stated range.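

In this assay, among the compounds shown here, the one step that can be read at this position is a number 46 percentage points higher from compound 2 to compound 4 (beyond the scatter), with 3-carboxy-4-methoxyphenyl in place of phenyl on an aromatic carbon, and it shows that changing the group here can move the percent remaining by far more than repeat measurements would. The steps involving compound 1 or compound 3 cannot be read, as neither has a number, so the swap of 2-fluoro-4-(trifluoromethyl)phenyl for 3-carboxy-4-methoxyphenyl has a computed description but no measured size. The information given contains no separate measurement that could explain the rise seen with compound 4.

The step to compound 4 adds a carboxylic acid and a methoxy group at once, and the compounds shown do not separate them, so it remains open whether either group alone would give the same rise. On these data alone, it also remains open whether a primary amide or a nitrile in place of the carboxylic acid, or an ethoxy group in place of the methoxy group, would keep this much of the compound intact.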